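Lengthening the Hexyl-Type Chain on a Fluorinated Anilino Core

The source may report more compounds than this note shows. Statements on the series, on what has been measured and on what is new or still open speak of the compounds shown alone.

The series was followed in an assay on mitochondria from L6 cells (Rattus norvegicus) for activation, with a stated time of 90 min; a higher number here means that more compound is needed for the effect, a lower number that less compound is needed. Compound 1 `CCCCCCc1ccc(Nc2nc3nonc3nc2O)cc1` gives 4700 nM. Compound 2 `CCCCCc1ccc(Nc2nc3nonc3nc2O)c(F)c1` gives 1500 nM, the lowest of the two numbers on record, and the number for compound 1 is higher by a margin that lies beyond the usual scatter. Among the measured compounds shown here, compound 1 and compound 2 differ in more than one place, so no single step between them can be read.

Compound 3 `CCCCCCc1ccc(Nc2nc3nonc3nc2O)c(F)c1` is the next member. Going from compound 2 to compound 3, the change is methyl in place of hydrogen on a saturated chain carbon, five bonds along the chain from an aromatic carbon. For the measured compounds named here, no measured pair shows this change on its own, so its size has to be judged without a direct precedent.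

Since nothing on record isolates this change, compound 3 is expected to land near compound 2, with a step of a 1.2-fold higher number from compound 2 to compound 3 (0.08 log units; within the scatter) that should sit within the scatter or just at its edge. Compound 3 is therefore estimated at 1800 nM in this assay, within a range of 700 nM to 4500 nM.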

Compound 3, half-maximal effective concentration: 3300 nM
Compound 3: the middle estimate sits 1.8-fold (0.26 log units) below what was measured, within the range that was stated.
By their numbers in this assay, from the lowest: compound 2; then compounds 3 and 1 (each within the scatter of the next).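

In this assay, methyl in place of hydrogen on a saturated chain carbon, five bonds along the chain from an aromatic carbon, can now be read on its own, and it gives a 2.2-fold higher number from compound 2 to compound 3 (0.34 log units; beyond the scatter), a modest step that still clears the scatter, so a single added carbon at this place on the chain does register. Fluoro in place of hydrogen on an aromatic carbon can also be read for the first time, and at a 1.4-fold lower number from compound 1 to compound 3 (0.15 log units; within the scatter) it stays inside the scatter, so with this longer chain in place the numbers do not separate fluoro from hydrogen. No measurement at hand offers an explanation for either step.

With only one step along the chain, the compounds shown leave open whether a heptyl chain would carry the trend further, or whether a butyl chain would run the other way. They also leave open whether the fluoro replacement would read the same on the shorter chain of compound 2, and whether chloro on that aromatic carbon, or an amine or a carboxylic acid on the chain, would move the number at all.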